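Methoxy to hydroxy on the aryl group of compound 1

This account rests on a few compounds, and the source may have more. Where it says the series, first, only, none or still open, it means among the compounds named here.

Measured so far in an ADME assay on HEL cells (Homo sapiens) for cytotoxicity, with a stated time of 3 days; a lower number here means that less compound is tolerated, a higher number that more compound is tolerated:
- compound 1 `COc1cccc(-c2cc(C)c3ncc(CSCCc4ccccc4)n3c2)c1`: 20 ug/mL
- compound 2 `Cc1cc(-c2cccs2)c2ncc(CSCCc3ccccc3)n2c1`: 100 ug/mL
- compound 3 `Cc1cc(-c2ccccc2)c2ncc(CSCCc3ccccc3)n2c1`: 20 ug/mL

Compound 1 stands level with compound 3 at the digits printed, and the two together give the lowest numbers of the three. Among the compounds with values here, the one measured step within the set is a 5.0-fold lower number from compound 2 to compound 3 (0.70 log units; beyond the scatter), and it concerns the aryl group on the shared core, not the substituent on that aryl group.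

Compound 4 `Cc1cc(-c2cccc(O)c2)cn2c(CSCCc3ccccc3)cnc12` is the next compound to be measured. It differs from compound 1 in one place: hydrogen in place of methyl on an oxygen on an aromatic ring. The same difference read one bond further out is methoxy to hydroxy, or 3-methoxyphenyl to 3-hydroxyphenyl.

Within the data shown here, no measured step bears on this change. Among the measured compounds shown here, the only step that exists, from compound 2 to compound 3, replaces one aryl group by another and says nothing about what a hydroxy does in place of a methoxy. What the numbers do show is that compound 1 and compound 3, which carry a methoxy-bearing phenyl and a bare phenyl, give the same number at the digits printed, so the substituent on the phenyl has not yet moved this assay. On that basis the step of no change at the digits printed from compound 1 to compound 4 (within the scatter) is expected to stay within the scatter. For compound 4 the estimate is 20 ug/mL, with a range from 10 ug/mL to 50 ug/mL.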

Compound 4, minimum cytotoxic concentration: 20 ug/mL
Compound 4: the middle estimate sits on the measured number at the digits printed, and the stated range covers the measured number.
By their numbers in this assay, from the lowest: compounds 1, 3 and 4 (each within the scatter of the next); then compound 2.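

In this assay hydrogen in place of methyl on an oxygen on an aromatic ring gives no change at the digits printed from compound 1 to compound 4 (within the scatter) and so the 3-methoxyphenyl and 3-hydroxyphenyl groups cannot be told apart in this read-out. Within the data shown here, this is the first measured step that concerns the substituent on the aryl group and not the aryl group itself, since the only earlier step, a 5.0-fold lower number from compound 2 to compound 3 (0.70 log units; beyond the scatter), exchanged thiophen-2-yl for phenyl. Nothing available here accounts for the absence of a shift between methoxy and hydroxy.

Among these compounds, the result covers only this one exchange on this one aryl group, so it remains open whether an amine, a carboxylic acid or a longer alkoxy chain in the same place would also leave the number within the scatter. Also open, on these data alone, is whether any change to a substituent on the phenyl group can move the minimum cytotoxic concentration beyond the scatter, as the exchange of the aryl group itself did in the step to compound 3.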